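This account rests on a few compounds, and the source may have more. Where it says the series, first, only, none or still open, it means among the compounds named here.

Going by the values given here, compound 2, with the structure `C#CCSC[C@H](NC(=O)c1cc(O)cc(O)c1)C(=O)OC`, is one of two compounds measured in an assay on RAW264.7 cells for antagonist activity at Toll-like receptor 2 (Mus musculus), read by Griess assay, with a stated time of 24 h; on this read-out lower numbers stand for stronger inhibition and higher numbers for weaker inhibition. In this assay compound 2 gives 41800 nM. Among the compounds with values here, its only neighbour is compound 1, with the structure `C=CCCSC[C@H](NC(=O)c1cc(O)cc(O)c1)C(=O)OC`, which in this assay gives 35800 nM. The step between them, a 1.2-fold higher number from compound 1 to compound 2 (0.07 log units; within the scatter), is ethynyl in place of allyl on a saturated chain carbon bound to a sulfur, and the two numbers do not differ beyond the scatter. Compound 3, with the structure `COC(=O)[C@H](CSCc1ccc(F)cc1)NC(=O)c1cc(O)cc(O)c1`, has not yet been measured. It differs from compound 2 by 4-fluorophenyl in place of ethynyl on a saturated chain carbon bound to a sulfur; cut one bond further out, the change reads propargyl to 4-fluorobenzyl. Within the data shown here, only the step from compound 1 to compound 2 bears on this change, and it was small, so the one swap seen at this position left the number essentially unchanged. Among the measured compounds shown here, a ring enters here, and no measured step covers such a change, so the expected step of a 1.3-fold lower number from compound 2 to compound 3 (0.10 log units; within the scatter) for compound 3 is none beyond the scatter, with a wide range. Compound 3 is therefore estimated at 33000 nM in this assay, between 8000 nM and 130000 nM.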

Compound 3, half-maximal inhibitory concentration: 38400 nM
Compound 3: the middle estimate sits 1.2-fold (0.07 log units) below what was measured; low and high end bracket the measured number.
By their numbers in this assay, from the lowest: compounds 1, 3 and 2 (each within the scatter of the next).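

In this assay, the first ring at this position gives a 1.1-fold lower number from compound 2 to compound 3 (0.04 log units; within the scatter) and, measured against the allyl compound, a 1.1-fold higher number from compound 1 to compound 3 (0.03 log units; within the scatter) in the same read-out. The earlier step covered only a swap between two small open chains, whereas these two steps show that a 4-fluorophenyl group, with its six-membered aromatic ring and larger count of heavy atoms, also leaves the number within the scatter when placed on a saturated chain carbon bound to a sulfur. Across these three compounds, none of which goes against this pattern, the change from propargyl to 4-fluorobenzyl therefore brings no readable gain or loss, and no measurement is available to explain why the numbers stay so close.

On these data alone, all three groups on this chain carbon are built from carbon, apart from the single fluorine, so it remains open whether an amine, a carboxylic acid or a much longer chain would move the number beyond the scatter. The shared core is also the same in all three compounds, which leaves open what a change anywhere else would do.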